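Swapping the aryl group: from compound 3 to compound 4

The source may hold more compounds than are shown below. What is called first, only, known or untested is meant among the compounds shown, and "the series" means these compounds.

Compound 1 `C=C1C[C@]23C[C@@]1(O)CC[C@H]2c1ccc(O)c(C)c1[C@@H]3Cn1cc(-c2ccccn2)nn1` gives > 20000 nM in a functional assay on HL-60 cells (Homo sapiens) for cytotoxicity, read by MTT assay, with a stated time of 4 days (a lower number here means a stronger inhibitor, a higher number a weaker inhibitor), a limit of the assay and not a number. Compound 2 `C=C1C[C@]23C[C@@]1(O)CC[C@H]2c1cc(Br)c(O)c(C)c1[C@@H]3Cn1cc(-c2ccc(OC)cc2)nn1` gives > 20000 nM in this assay, again a limit. Compound 3 `C=C1C[C@]23C[C@@]1(O)CC[C@H]2c1cc(Br)c(O)c(C)c1[C@@H]3Cn1cc(-c2ccccn2)nn1` gives > 20000 nM in this assay, also a limit.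

Compound 3 therefore stands where every value shown stands: at the limit of > 20000 nM in this assay, at which 3 of the 3 values shown sit. Two changes lead into it. The step that the two limits leave unreadable from compound 1 to compound 3 and the step that the two limits leave unreadable from compound 2 to compound 3 both run between two limits, so neither tells whether swapping groups on the shared core moves potency at all. The not yet measured compound 4 `C=C1C[C@]23C[C@@]1(O)CC[C@H]2c1cc(Br)c(O)c(C)c1[C@@H]3Cn1cc(-c2ccc(Cl)cc2)nn1` differs from compound 3 by 4-chlorophenyl in place of pyridin-2-yl on an aromatic carbon. Going by the values given here, no measured step bears readably on this change, since every number around it is a limit. With three limits and nothing else, compound 4 is expected to sit at the limit as well, an estimated 30000 nM with a range of 12000 nM to 100000 nM. The expected step that the limit leaves unreadable from compound 3 to compound 4 is accordingly none beyond the scatter.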

Compound 4, half-maximal inhibitory concentration: 5590 nM
Estimate against measurement, compound 4: 5.4-fold (0.73 log units) above; the whole stated range lies above it.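

Replacing pyridin-2-yl with 4-chlorophenyl gives an at least 3.5-fold lower number from compound 3 to compound 4 (0.55 log units; beyond the scatter), which shows that the group on this aromatic carbon of the five-membered ring can change the result in this assay. Chloro in place of methoxy gives an at least 3.5-fold lower number from compound 2 to compound 4 (0.55 log units; beyond the scatter), so the benzene ring alone does not account for the gain, and the group it carries matters too. Compound 4 is the first of these compounds with a value that can be read as a number, whereas the earlier results gave no measure of any change: the limit of > 20000 nM in this assay, at which 3 of the 4 values shown sit.

Still open, on these data alone, is how far potency moves with other groups on that benzene ring, such as an amine, a carboxylic acid or a longer alkyl chain. Also open, as far as these compounds go, is what the bromo contributes when 4-chlorophenyl is present.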